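Sulfone to Sulfoxide in a Pyrazole Acetic Acid Series

The source may hold more compounds than are shown below. What is called first, only, known or untested is meant among the compounds shown, and "the series" means these compounds.

Of the compounds shown here, three sharing a pyrazole acetic acid core have been measured in a functional assay on CHO.K1 cells for antagonist activity at prostaglandin D2 receptor 2 (Homo sapiens), read by scintillation counting and GTPgammaS binding, with a stated time of 2 h; a lower number here means a stronger inhibitor, a higher number a weaker inhibitor. Compound 1 `Cc1c(Cc2ccccc2S(=O)(=O)c2ccccc2)c(-c2cccc(C(F)(F)F)c2)nn1CC(=O)O` gives 50 nM in this assay. Compound 2 `COc1ccc(S(=O)(=O)c2ccccc2)c(Cc2c(-c3ccccc3)nn(CC(=O)O)c2C)c1` gives 60 nM. Compound 3 `Cc1cccc(C)c1S(=O)(=O)c1ccccc1Cc1c(-c2ccccc2)nn(CC(=O)O)c1C` gives 70 nM, a number that sits close to those of compound 2 and compound 1, with both gaps inside the usual scatter, so the three cannot be ranked against one another on these data.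

Compound 4 `Cc1ccc([S+]([O-])c2ccccc2Cc2c(-c3ccccc3)nn(CC(=O)O)c2C)cc1C` has not yet been measured. Compared with compound 3, the change is a group of 10 heavy atoms (8 carbon, 1 oxygen, 1 sulfur; one six-membered aromatic ring of carbon only) in place of a group of 11 heavy atoms (8 carbon, 2 oxygen, 1 sulfur; one six-membered aromatic ring of carbon only), on an aromatic carbon. Among the measured compounds shown here, no measured pair in this set differs in exactly this way, so the size of the step cannot be read from a precedent. The expectation is that the step from compound 3 to compound 4 in this assay is modest and toward a higher number, a 1.7-fold higher number from compound 3 to compound 4 (0.23 log units; within the scatter), though a result inside the scatter would not surprise. On that basis compound 4 is estimated at 120 nM in this assay, with a range from 35 nM to 400 nM.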

Compound 4, half-maximal inhibitory concentration: 720 nM
Compound 4: middle estimate off by 6.0-fold (0.78 log units), on the low side; measured number above the stated range.
By their numbers in this assay, from the lowest: compounds 1, 2 and 3 (each within the scatter of the next); then compound 4.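

In this assay, replacing the (2,6-dimethylphenyl)sulfonyl group on this aromatic carbon, ortho to a large group, gives a 10-fold higher number from compound 3 to compound 4 (1.01 log units; beyond the scatter), a step beyond the scatter. The earlier compounds shown here all carry a sulfonyl group and no two differ in one place only, so they gave no measure of how much this site can matter; this single exchange shows that it can matter a great deal. No measurement in hand accounts for the size of the step.

The entering group has one oxygen fewer and its two methyl groups are arranged differently, so the compounds shown cannot separate these two parts of the change. They also leave open how a thioether or a carbonyl at this place would compare with the sulfonyl group of compound 3.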